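The compounds below may be only part of what the source reports. "The series", "measured", "known", "first", "only" and "open" are said of these compounds alone.

The comparison begins with compound 3 `CCCc1ccc(-c2ccc3ncc(-c4noc(C)n4)cc3c2)cc1`. In a functional assay on RD cells (Homo sapiens) for inhibition, read by luminescence and ATP content, with a stated time of 72 h (a higher number here means that more compound is tolerated, a lower number that less compound is tolerated), compound 3 gives only a limit, > 7400 nM. Its neighbours in the series fare alike. Compound 1 `CCCc1ccc(-c2ccc3ncc(C(=O)OCC)cc3c2)cc1` differs from it only in one group on the shared core, and the step that the two limits leave unreadable from compound 1 to compound 3 cannot be read. For compound 1 the result in this assay is likewise a limit, > 7400 nM. Compound 2 `FC(F)(F)c1nc(-c2cnc3ccc(-c4ccc(Cl)cc4)cc3c2)no1` is the third member, and for compound 2 the result in this assay is also a limit, > 200000 nM. Two of the three values thus sit at the limit of > 7400 nM in this assay, at which 2 of the 3 values shown sit, and the remaining one at the limit of > 200000 nM in this assay, at which 1 of the 3 values shown sits, so compound 3 stands on no number at all but at one of the two limits.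

Compound 4 `COc1ccc(-c2ccc3ncc(-c4noc(C)n4)cc3c2)cc1` arises from compound 3 by methoxy in place of propyl on an aromatic carbon. Going by the values given here, no measured step tests this exchange: the only step available, a step that the two limits leave unreadable from compound 1 to compound 3, touches a different group and is itself unreadable between two limits. Nothing in the series points to a change in this assay beyond the scatter, and with both neighbours ending at limits, the likeliest outcome is that compound 4 also returns a limit. The step that the limit leaves unreadable from compound 3 to compound 4 is accordingly estimated to be small. Compound 4 is expected to give about 30000 nM, within a range from 7400 nM to 200000 nM, most probably reported only as a limit.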

Compound 4, half-maximal cytotoxic concentration: > 66700 nM
Compound 4: only a limit was reported; the forecaster's own chance of this, stated with the estimate: 85%; middle value at least 2.2-fold (0.34 log units) from the limit.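

In this assay, compound 3 and compound 4 both give only limits, so the step between them, methoxy in place of propyl, cannot be read. The compounds shown leave open what the half-maximal cytotoxic concentration of each compound actually is, and whether this exchange changes it at all.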